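A Chloro Added to the Nitrophenyl Hydrazone

A few compounds are considered here, and "the series" means these few. Any claim that something is new, unique, unknown or untested is made for them only; others in the source may bear on it.

Compound 1 `Cn1c(=O)c(=O)n(C2CCCC2)c2nc(N/N=C/c3ccc(F)cc3Br)ncc21`: 6590 nM
Compound 2 `Cn1c(=O)c(=O)n(C2CCCC2)c2nc(N/N=C/c3cccc([N+](=O)[O-])c3)ncc21`: 12300 nM

Both were tested in a functional assay on A549 cells (Homo sapiens) for antiproliferative activity, read by MTT assay; a higher number here means a weaker inhibitor, a lower number a stronger inhibitor. In this assay compound 2 gives 12300 nM, the larger of the two numbers shown, with compound 1 nearest at 6590 nM; the step of a 1.9-fold higher number from compound 1 to compound 2 (0.27 log units; within the scatter). Compound 3 `Cn1c(=O)c(=O)n(C2CCCC2)c2nc(N/N=C/c3cc([N+](=O)[O-])ccc3Cl)ncc21` is not yet measured and differs from compound 2 by chloro in place of hydrogen on an aromatic carbon. Within the data shown here, the only measured step swapped the whole aryl group, so it bears only loosely on this smaller change, and no step beyond the scatter is expected. The estimate for compound 3 is 8000 nM (range 3000 nM to 20000 nM). That means an expected step of a 1.5-fold lower number from compound 2 to compound 3 (0.19 log units; within the scatter).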

Compound 3, half-maximal inhibitory concentration: 8780 nM
The estimate for compound 3 lay 1.1-fold (0.04 log units) below the measured number; the range from low to high includes it.
By their numbers in this assay, from the lowest: compounds 1, 3 and 2 (each within the scatter of the next).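

Placing chloro para to the nitro group gives a 1.4-fold lower number from compound 2 to compound 3 (0.15 log units; within the scatter), so in this assay this position takes one added chlorine atom with no change that can be told from scatter. The other comparison, with the whole aryl group exchanged, gives a 1.3-fold higher number from compound 1 to compound 3 (0.12 log units; within the scatter), so the three aryl groups shown cannot be told apart here. Nothing measured here offers a cause for this result. On these data alone, whether an amine or a carboxylic acid on this same ring carbon would move the number beyond the scatter remains open.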